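Series notes: aryl variation on the shared core

The source may report more compounds than this note shows. Statements on the series, on what has been measured and on what is new or still open speak of the compounds shown alone.

Measured compounds:
- compound 1, `CC(C)c1onc(-c2ccccc2Cl)c1COc1ccc(COc2ccc(OCC(=O)O)cc2)cc1`: 4700 nM
- compound 2, `CC(C)c1onc(-c2ccccc2C(F)(F)F)c1COc1ccc(CCCC(=O)O)cc1`: 4400 nM
- compound 3, `Cc1cccc(C)c1-c1noc(C(C)C)c1COc1ccc(CCCC(=O)O)cc1`: 7700 nM

All three numbers come from an assay on HEK-293T cells for activation of Bile acid receptor (Homo sapiens), read by a luciferase reporter, with a stated time of 14 h; a higher number here means that more compound is needed for the effect, a lower number that less compound is needed. Compound 3 sits at the upper end of the three values, but its gaps to compound 1 and to compound 2 both lie within the scatter, so no ranking among the three is supported.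

Compound 4 is `CC(C)c1onc(-c2ccccc2Cl)c1COc1ccc(CCCC(=O)O)cc1`, not yet measured. It differs from compound 3 in one place: 2-chlorophenyl in place of 2,6-dimethylphenyl on an aromatic carbon.

Among the compounds with values here, one measured step bears on this change: a 1.8-fold higher number from compound 2 to compound 3 (0.24 log units; within the scatter), which exchanged one aryl group for another at the same position and stayed within the scatter. Within the data shown here, compound 1 also carries 2-chlorophenyl, but with a different acid-bearing chain, so no direct step to compound 4 exists; its value and that of compound 3 are within the scatter of each other.

On this basis the expected step of a 1.5-fold lower number from compound 3 to compound 4 (0.19 log units; within the scatter) is small, if anything toward a lower number, and not clearly beyond the scatter. Compound 4 is therefore estimated at 5000 nM, with a range of 2500 nM to 10000 nM.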

Compound 4, half-maximal effective concentration: 3800 nM
The estimate for compound 4 lay 1.3-fold (0.12 log units) above the measured number, and the stated range covers the measured number.
By their numbers in this assay, from the lowest: compounds 4, 2, 1 and 3 (each within the scatter of the next, the first and the last beyond it).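

In this assay, within the data shown here, on the aromatic carbon next to the ring nitrogen, 2-chlorophenyl in place of 2,6-dimethylphenyl gives a 2.0-fold lower number from compound 3 to compound 4 (0.31 log units; beyond the scatter) and is the first aryl change here to pass the scatter, though only modestly. Chloro in place of trifluoromethyl does not separate the two ortho-substituted aryl groups, giving a 1.2-fold lower number from compound 2 to compound 4 (0.06 log units; within the scatter) as the step, and with 2-chlorophenyl held fixed the chain change gives a 1.2-fold lower number from compound 1 to compound 4 (0.09 log units; within the scatter) and leaves these two acid-bearing chains unseparated as well. No measured evidence accounts for the difference between 2-chlorophenyl and 2,6-dimethylphenyl.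

Still open, as far as these compounds go, is how 2,6-dichlorophenyl or unsubstituted phenyl would compare at this position. The shown compounds also leave open what an amide or a tetrazole in place of the carboxylic acid would give.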